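The source may report more compounds than this note shows. Statements on the series, on what has been measured and on what is new or still open speak of the compounds shown alone.

Measured compounds in an assay for inhibition of Amine oxidase [flavin-containing] B (Rattus norvegicus); on this read-out lower numbers stand for stronger inhibition and higher numbers for weaker inhibition:

- compound 1 `NC(=O)Cc1cc(=O)oc2cc(OCc3ccccc3)ccc12`: 200 nM
- compound 2 `NC(=O)Cc1cc(=O)oc2cc(OCc3cccc(Cl)c3)ccc12`: 30 nM
- compound 3 `NC(=O)Cc1cc(=O)oc2cc(OCc3cccc(F)c3)ccc12`: 50 nM

Compound 3 stands second highest of the three numbers in this assay; its nearest neighbour is compound 2, with a 1.7-fold higher number from compound 2 to compound 3 (0.22 log units; within the scatter), and its furthest is compound 1, with a 4.0-fold lower number from compound 1 to compound 3 (0.60 log units; beyond the scatter).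

Compound 4 `NC(=O)Cc1cc(=O)oc2cc(OCc3cccc(O)c3)ccc12` differs from compound 3 by hydroxy in place of fluoro on an aromatic carbon. The measured steps at this place involve only hydrogen and halogens: a 6.7-fold lower number from compound 1 to compound 2 (0.82 log units; beyond the scatter) and a 4.0-fold lower number from compound 1 to compound 3 (0.60 log units; beyond the scatter), both modest, and the halogen swap from compound 2 to compound 3 within the scatter. Within the data shown here, no measured compound carries a hydroxy, or any donor, at this position, so the step is weakly anchored. For compound 4 the expected step is a 2.0-fold higher number from compound 3 to compound 4 (0.30 log units; within the scatter), a drift back toward the level of compound 1. Compound 4 is estimated at 100 nM, range 30 nM to 400 nM.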

Compound 4, half-maximal inhibitory concentration: 1000 nM
The estimate for compound 4 lay 10-fold (1.00 log units) below the measured number; the measured number lies above the stated range.
By their numbers in this assay, from the lowest: compounds 2 and 3 (each within the scatter of the next); then compound 1; then compound 4.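

In this assay the change to 3-hydroxybenzyl reverses the direction seen with the halogens: hydroxy gives a 20-fold higher number from compound 3 to compound 4 (1.30 log units; beyond the scatter) and a 33-fold higher number from compound 2 to compound 4 (1.52 log units; beyond the scatter) and even loses ground to plain benzyl, with a 5.0-fold higher number from compound 1 to compound 4 (0.70 log units; beyond the scatter) at this place. Substitution on this aromatic carbon therefore does not lower the number as such; the outcome depends on which group enters. No evidence on the origin of this reversal is available.

On these data alone, how methoxy or an amine would read at this place remains open, and so does whether the loss is particular to hydroxy.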